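Cytotoxicity notes: from compound 2 to compound 3

This account rests on a few compounds, and the source may have more. Where it says the series, first, only, none or still open, it means among the compounds named here.

Measured in an ADME assay on HepG2 cells (Homo sapiens) for cytotoxicity; on this read-out higher numbers stand for lower toxicity in this test and lower numbers for higher toxicity in this test:
- compound 1 `C[C@H]1CC(C)(C)Nc2c(C(=O)N[C@H](/C=C/S(=O)(=O)c3ccccc3)CCc3ccccc3)cccc21`: > 300000 nM
- compound 2 `Cc1ncn(C)c1C(=O)N[C@H](/C=C/S(=O)(=O)c1ccccc1)CCc1ccccc1`: 34400 nM

Compound 1 gives > 300000 nM, and this is a limit of the assay, not a number. Going by the values given here, compound 2 gives 34400 nM, the only actual number so far, and so it is the sole reference point in this assay. Among the compounds with values here, no measured pair differs in one place, so the size of a single change has not been observed.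

The next compound to be tested is compound 3 `O=C(N[C@H](/C=C/S(=O)(=O)c1ccccc1)CCc1ccccc1)c1ccc([N+](=O)[O-])s1`. It carries 5-nitrothiophen-2-yl in place of 1,4-dimethyl-1H-imidazol-5-yl on a carbonyl carbon, and the rest of the structure matches compound 2: 5-nitrothiophen-2-yl in place of 1,4-dimethyl-1H-imidazol-5-yl on a carbonyl carbon.

Within the data shown here, the expectation is anchored on compound 2 at 34400 nM, and it has to allow wide margins with no measured step to guide it. A modest move towards a lower number in this assay is expected, and the expected step is a 1.6-fold lower number from compound 2 to compound 3 (0.19 log units; within the scatter). Compound 3 is estimated at 22000 nM, with an expected range of 6000 nM to 80000 nM.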

Compound 3, half-maximal cytotoxic concentration: 12400 nM
For compound 3 the middle estimate is 1.8-fold (0.25 log units) above the measured one, within the range that was stated.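

In this assay, the group on a carbonyl carbon whose other neighbour is the amide-type nitrogen now proves able to shift the read-out on its own: 5-nitrothiophen-2-yl in place of 1,4-dimethyl-1H-imidazol-5-yl gives a 2.8-fold lower number from compound 2 to compound 3 (0.44 log units; beyond the scatter). Going by these compounds alone, this is the first single-place step available, and although modest, it lies beyond the usual scatter, so the choice of ring at this position registers in this test while the rest of the structure stays the same. Compound 1 gives > 300000 nM, which is a limit of the assay and not a number, so steps to it cannot be read: the limit of > 300000 nM in this assay, at which 1 of the 3 values shown sits.

Within the data shown here, the nitro group and the thiophene ring enter together, so the single step does not separate them; a plain thiophen-2-yl or a 5-cyanothiophen-2-yl on the same carbonyl carbon would part the two. Also open, from the compounds shown here alone, is whether the lower number in this assay is tied to an aromatic ring at all, which a saturated cyclohexyl group at this position would address.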